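The source may report more compounds than this note shows. Statements on the series, on what has been measured and on what is new or still open speak of the compounds shown alone.

Compound 1 `Cc1ccc(CS(=O)(=O)/C(=C/c2cc(C)cc(C)c2)C(=O)c2ccc(Cl)cc2)cc1`: 10000 nM
Compound 2 `COc1cc(OC)c(/C=C(\C(=O)c2ccc(Br)cc2)S(=O)(=O)c2ccc(Br)cc2)c(OC)c1`: > 100000 nM

In a functional assay on DU-145 cells (Homo sapiens) for inhibition, read by trypan blue exclusion, with a stated time of 96 h (a lower number here means a stronger inhibitor of growth, a higher number a weaker inhibitor of growth), compound 1 gives 10000 nM. Compound 2 gives > 100000 nM, which is a limit of the assay and not a number. Compound 2 therefore stands at the limit of > 100000 nM in this assay, at which 1 of the 2 values shown sits.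

Compound 3 `COc1cc(OC)c(/C=C(/SCc2ccc(Cl)cc2)C(=O)c2ccc(Br)cc2)c(OC)c1` has not yet been measured. It departs from compound 2 at a single place: (4-chlorobenzyl)sulfanyl in place of (4-bromophenyl)sulfonyl on a double-bonded chain carbon bound to a carbonyl carbon and a double-bonded chain carbon. Among the compounds with values here, no measured step shows what such an exchange does, so any expectation rests on little. Within the data shown here, the only numerical value available is that of compound 1, at 10000 nM, and it is the one measured figure on which an expectation can lean. A moderate gain in growth inhibition is expected, although compound 3 could also stay at the limit. The estimated change is an at least 5.0-fold lower number from compound 2 to compound 3 (0.69 log units; beyond the scatter). For compound 3 the expected value is 20000 nM, with an estimated range of 3000 nM to 100000 nM.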

Compound 3, concentration for 50% growth inhibition: 1000 nM
Compound 3: middle estimate off by 20-fold (1.30 log units), on the high side; the measured number lies below the stated range.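

In this assay, (4-chlorobenzyl)sulfanyl in place of (4-bromophenyl)sulfonyl on a double-bonded chain carbon bound to a carbonyl carbon and a double-bonded chain carbon gives an at least 100-fold lower number from compound 2 to compound 3 (2.00 log units; beyond the scatter). Within the data shown here, this is the one measured step at this position, and it shows that growth inhibition depends strongly on the group that stands there. The true size of the step remains unknown because compound 2 stands at a limit of the assay and not at a number: the limit of > 100000 nM in this assay, at which 1 of the 3 values shown sits.

The exchange alters the sulfur group, the link to the ring and the halogen together, so the compounds shown do not tell which of these changes carries the step. Also open, as far as these compounds go, is whether a (4-chlorophenyl)sulfanyl group or an amine at this place would keep the lower number of compound 3.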